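Extending methylamino to benzylamino: an expected half-life

A few compounds are considered here, and "the series" means these few. Any claim that something is new, unique, unknown or untested is made for them only; others in the source may bear on it.

Compound 1, `CCOC(=O)N1C(=O)[C@@H](CC)[C@@H]1Oc1ccc(C(=O)O)cc1`: in a physicochemical assay for pharmacokinetics (on this read-out lower numbers stand for a shorter-lived compound and higher numbers for a longer-lived compound), compound 1 gives 29.7 h.
Compound 2, `CC[C@@H]1C(=O)N(C(=O)NC)[C@H]1Oc1ccc(C(=O)O)cc1`: in this assay compound 2 reaches >> 80 h, which is a limit of the assay and not a number.

Within the data shown here, compound 2 therefore stands at the upper edge of what this assay has resolved, and the size of the one step leading to it, an at least 2.6-fold higher number from compound 1 to compound 2 (0.43 log units; beyond the scatter), is bounded by the limit of >> 80 h in this assay, at which 1 of the 2 values shown sits. Compound 3, `CC[C@@H]1C(=O)N(C(=O)NCc2ccccc2)[C@H]1Oc1ccc(C(=O)O)cc1`, differs from compound 2 by phenyl in place of hydrogen on a saturated chain carbon bound to an amide-type nitrogen. Among the measured compounds shown here, no measured step covers this change. Since compound 2 already sits at the limit, compound 3 is expected to remain long-lived, with the step that the limit leaves unreadable from compound 2 to compound 3 being an estimate only. Compound 3 is expected to give 150 h, between 40 h and 500 h.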

Compound 3, half-life: >> 80 h
Compound 3 was reported as a limit (the forecaster's own chance of this, stated with the estimate: 70%); the middle value lies beyond the limit too.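

Benzylamino in place of ethoxy gives an at least 2.6-fold higher number from compound 1 to compound 3 (0.43 log units; beyond the scatter) in this assay, so the larger group on this carbonyl carbon still gives a longer-lived compound than ethoxy, as methylamino did. The added phenyl therefore does not bring the half-life back down into the range the assay can read. Its exact effect cannot be read, because compound 2 and compound 3 both give a limit and not a number: the limit of >> 80 h in this assay, at which 2 of the 3 values shown sit. On these data alone, whether phenyl lengthens or shortens the half-life remains open. So does the behaviour of a dimethylamino group on the same carbonyl carbon.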